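A few compounds are considered here, and "the series" means these few. Any claim that something is new, unique, unknown or untested is made for them only; others in the source may bear on it.

Compound 2 `COc1ccc(-c2cc3ccccc3nc2/C=C/C(=O)c2ccco2)cc1` stands lowest of the two numbers recorded in a functional assay on MDA-MB-231 cells (Homo sapiens) for antiproliferative activity, read by XTT assay, with a stated time of 72 h; on this read-out lower numbers stand for stronger inhibition and higher numbers for weaker inhibition: compound 2 gives 630 nM, while compound 1 `COc1ccc(-c2cc3ccccc3nc2/C=C/C(=O)c2c(OC)cccc2OC)cc1` gives 5630 nM. For the measured compounds named here, the only measured step, an 8.9-fold lower number from compound 1 to compound 2 (0.95 log units; beyond the scatter), shows that the group on the carbonyl carbon can move the number well beyond the scatter. Compound 3 `COc1ccc(-c2cc3ccccc3nc2/C=C/C(=O)c2cnc(N)nc2C)cc1` carries the change (2-amino-4-methylpyrimidin-5-yl in place of furan-2-yl on a carbonyl carbon). Going by the values given here, no measured step covers this new group, so the direction rests on that single precedent and stays uncertain. The expected step is a 1.9-fold higher number from compound 2 to compound 3 (0.28 log units; within the scatter). Compound 3 is therefore estimated at 1200 nM, within a range from 350 nM to 5000 nM.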

Compound 3, half-maximal inhibitory concentration: > 10000 nM
Compound 3 gave a limit, no number; the forecaster's own chance of this, stated with the estimate: 3%; middle value at least 8.3-fold (0.92 log units) from the limit.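

Compound 3 gives a limit of the assay, not a number: the limit of > 10000 nM in this assay, at which 1 of the 3 values shown sits. Putting 2-amino-4-methylpyrimidin-5-yl in place of furan-2-yl on the carbonyl carbon gives an at least 15-fold higher number from compound 2 to compound 3 (1.20 log units; beyond the scatter), so both six-membered aromatic rings shown sit well above furan-2-yl in this assay. The other comparison reads an at least 1.7-fold higher number from compound 1 to compound 3 (0.24 log units; that floor lies within the scatter), and with that floor within the scatter, those two groups cannot be put in order.

The compounds shown leave open whether the amino group, the methyl group or the ring nitrogens account for the step. They also leave open how a plain phenyl or a thiophen-2-yl ring would compare with furan-2-yl here.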